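Methoxy to Nitro, Repeated on a Second Core

The source may report more compounds than this note shows. Statements on the series, on what has been measured and on what is new or still open speak of the compounds shown alone.

In an ADME assay on HEK-293T cells (Homo sapiens) for inhibition, read by CCK-8 assay, with a stated time of 48 h, tested at 20 uM (a higher number here means more inhibition of growth at the concentration tested, a lower number less inhibition of growth), compound 1 `COc1ccc(S(=O)(=O)Oc2ccccc2/C=C(\C#N)C(=O)Nc2nnc(Cc3ccc(F)cc3)s2)cc1` gives 20%. Compound 2 `N#C/C(=C\c1ccccc1OS(=O)(=O)c1ccc([N+](=O)[O-])cc1)C(=O)Nc1nnc(Cc2ccc(F)cc2)s1` differs from it by one change, (nitro in place of methoxy on an aromatic carbon), and in this assay compound 2 gives 8%; the step of a number 12 percentage points lower from compound 1 to compound 2 (beyond the scatter) is modest but real. Compound 3 `COc1ccc(S(=O)(=O)Oc2ccccc2/C=C(\C#N)C(=O)Nc2nnc(Cc3cccc(F)c3)s2)cc1` shares the core of compound 1 except for (3-fluorophenyl in place of 4-fluorophenyl on a saturated chain carbon bound to an aromatic carbon), and in this assay compound 3 gives 29%; the step of a number 9 percentage points higher from compound 1 to compound 3 (within the scatter) cannot be told apart from repeat measurement.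

Compound 4 `N#C/C(=C\c1ccccc1OS(=O)(=O)c1ccc([N+](=O)[O-])cc1)C(=O)Nc1nnc(Cc2cccc(F)c2)s1` has not been measured in this assay. It stands to compound 3 as compound 2 stands to compound 1: the change (nitro in place of methoxy on an aromatic carbon), the same change as before, made at the same kind of place. If the step seen from compound 1 to compound 2 carries over, the expected step of a number 12 percentage points lower from compound 3 to compound 4 (beyond the scatter) should be of similar size, resting on a number 12 percentage points lower from compound 1 to compound 2 (beyond the scatter). The starting point is the value of compound 3, 29%. The estimated result for compound 4 in this assay is therefore 17%, expected to fall between 5% and 28%.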

Compound 4, percent growth inhibition at one concentration: "not toxic" (no number reported)
Nothing numeric was reported for compound 4, and the estimate cannot be compared.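

Among the compounds shown here, compound 4 is recorded in this assay only as "not toxic", with no number, so no step from compound 3 to compound 4 can be read. No other data here bear on this result. Still open, going by these compounds, is whether nitro in place of methoxy shifts growth inhibition on the core of compound 3 as it did on the core of compound 1.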